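The source may hold more compounds than are shown below. What is called first, only, known or untested is meant among the compounds shown, and "the series" means these compounds.

Values in a functional assay on cells (Platelet, Homo sapiens) for inhibition; on this read-out lower numbers stand for stronger inhibition and higher numbers for weaker inhibition; each one is a limit of the assay, not a number:

- compound 1 `CCOC(=O)c1ccc(-c2nn(Cc3ccc(Cl)cc3)c3ccccc23)cc1`: > 10000 nM
- compound 2 `CCOC(=O)c1ccc(-c2nn(-c3ccco3)c3ccccc23)cc1`: > 10000 nM
- compound 3 `CCCOC(=O)c1ccc(-c2nn(Cc3ccccc3)c3ccccc23)cc1`: > 10000 nM

Compound 3 therefore has no exact position, only a limit. Compound 4 `NC(=O)c1ccc(-c2nn(Cc3ccccc3)c3ccccc23)cc1` differs from it by amino in place of propoxy on a carbonyl carbon, turning propoxycarbonyl into carbamoyl.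

Within the data shown here, the only measured step is a step that the two limits leave unreadable from compound 1 to compound 2. Among the measured compounds shown here, it concerns a different place and gives no size, so no measured step bears directly on this change. All that remains is the limit of > 10000 nM in this assay, at which 3 of the 3 values shown sit.

The expected step that the limit leaves unreadable from compound 3 to compound 4 is no clear change beyond the scatter, with no direction predicted. For compound 4 the estimate is 15000 nM, with an expected range of 4000 nM to 50000 nM.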

Compound 4, half-maximal inhibitory concentration: > 10000 nM
Compound 4 gave a limit, no number; the forecaster's own chance of this, stated with the estimate: 80%; the middle value is on the limit's open side.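

Among these compounds, compound 3 and compound 4 each give only a limit, and no step between them can be read. The compounds shown leave open whether any change to this series gives a measurable value in this assay.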